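A few compounds are considered here, and "the series" means these few. Any claim that something is new, unique, unknown or untested is made for them only; others in the source may bear on it.

Measured so far:
- compound 1, `CN1C(=O)N(c2ccccc2)C2NC(=S)N(/N=C/C=C/c3ccccc3)C21`: > 100000 nM
- compound 2, `CCN1C(=O)N(CC)C2C1NC(=S)N2/N=C/C=C/c1ccccc1`: 6530 nM

For the measured compounds named here, in a functional assay on A549 cells (Homo sapiens) for inhibition, read by MTT assay, with a stated time of 72 h (on this read-out higher numbers stand for weaker inhibition and lower numbers for stronger inhibition), compound 2 gives 6530 nM, the only plain number among the values shown. Compound 1 gives in this assay only a limit, > 100000 nM, and that limit is where one of the two values sits (the limit of > 100000 nM in this assay, at which 1 of the 2 values shown sits). No step between measured compounds that differ in one place is shown, so compound 2 stands alone as the single numbered point of the series.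

Compound 3, `CCN1C(=O)N(c2ccccc2)C2NC(=S)N(/N=C/C=C/c3ccccc3)C21`, has not yet been measured in this assay. Against compound 2 the change is phenyl in place of ethyl on an amide-type nitrogen in a ring. Compound 1 also bears a phenyl on the shared core, and in this assay compound 1 reaches only the limit > 100000 nM, so weaker inhibition is expected for the phenyl-bearing compound 3. The expected step is a 7.7-fold higher number from compound 2 to compound 3 (0.88 log units; beyond the scatter), toward weaker inhibition and beyond the scatter. Compound 3 is estimated at 50000 nM, with a range from 12000 nM to 150000 nM, and a real chance that only a limit is reported.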

Compound 3, half-maximal inhibitory concentration: > 100000 nM
Compound 3 ended at the assay's limit; the forecaster's own chance of this, stated with the estimate: 40%; middle value at least 2.0-fold (0.30 log units) away from the limit.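

In this assay the series now has its first readable change at this position: phenyl in place of ethyl on an amide-type nitrogen in a ring gives an at least 15-fold higher number from compound 2 to compound 3 (1.18 log units; beyond the scatter), a large move toward weaker inhibition. Compound 3 gives > 100000 nM, which is a limit of the assay and not a number, so the step has a lower bound and no upper end. The step between compound 1 and compound 3 cannot be read, since both values are limits, and neither compound with a phenyl on this nitrogen gives a plain number: the limit of > 100000 nM in this assay, at which 2 of the 3 values shown sit.

On these data alone, with only ethyl and phenyl seen on this nitrogen, it remains open whether methyl, a longer chain such as propyl or butyl, or a benzyl group would keep a readable value in this assay. Also open, as far as these compounds go, is whether a phenyl carrying a hydroxyl or an amine would bring the number back from the limit, and how far the second ring nitrogen's ethyl group contributes to the value of compound 2.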